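Amide aryl swap on a shared sulfonamide core

This account rests on a few compounds, and the source may have more. Where it says the series, first, only, none or still open, it means among the compounds named here.

Measured so far:
compound 1 `O=C(NCc1ccc(CNS(=O)(=O)c2ccc3c(c2)CCO3)cc1)c1scc2c1OCCO2` gives 68%
compound 2 `O=C(NCc1ccc(CNS(=O)(=O)c2ccc3c(c2)CCO3)cc1)c1cccnc1` gives 60%

Compound 1 and compound 2 share the same core and differ only in the group on the carbonyl carbon. In an assay on cells for inhibition of C-X-C chemokine receptor type 4 (Homo sapiens), with a stated time of 22 h, tested at 100 nM (on this read-out higher numbers stand for more inhibition at the one concentration tested (going by the name of the read-out) and lower numbers for less inhibition), compound 1 gives 68% and compound 2 gives 60%. For the measured compounds named here, the one step measured so far, a number 8 percentage points lower from compound 1 to compound 2 (within the scatter), is within the scatter, so the two numbers cannot be ordered. Compound 1 holds the higher of the two numbers, with compound 2 the nearest and not separable from it.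

Compound 3 `O=C(NCc1ccc(CNS(=O)(=O)c2ccc3c(c2)CCO3)cc1)c1cc2ccccn2n1` is not yet measured. Relative to compound 1 the change is a group of 9 heavy atoms (7 carbon, 2 nitrogen; one five-membered aromatic ring with 2 hetero atoms, one six-membered aromatic ring with 1 hetero atom) in place of a group of 9 heavy atoms (6 carbon, 2 oxygen, 1 sulfur; one five-membered aromatic ring with 1 hetero atom, one six-membered non-aromatic ring with 2 hetero atoms), on a carbonyl carbon. Going by the values given here, the only measured step that bears on this place is a number 8 percentage points lower from compound 1 to compound 2 (within the scatter), where a different group entered at the same carbonyl carbon and the number moved within the scatter. Taking that step as the guide, a change of about the same size, a number 6 percentage points lower from compound 1 to compound 3 (within the scatter), is expected, with no movement beyond the scatter in either direction. Compound 3 is therefore estimated at 62%, with a range from 45% to 78%.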

Compound 3, a percentage reported as inhibition, at one concentration (the size of the read-out at that concentration, not a potency): 40%
The estimate for compound 3 lay 22 percentage points above the measured number, and the stated range ends above it.
By their numbers in this assay, from the lowest: compound 3; then compounds 2 and 1 (each within the scatter of the next).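

In this assay, for the compounds shown here, the carbonyl carbon is not indifferent to the group it carries: there is a number 28 percentage points lower from compound 1 to compound 3 (beyond the scatter) and also a number 20 percentage points lower from compound 2 to compound 3 (beyond the scatter), the first steps that lie beyond the scatter. Heavy-atom count does not follow these numbers, since the groups of compound 1 and compound 3 both have 9 heavy atoms yet are separated beyond the scatter, whereas the 6-heavy-atom group of compound 2 stays within the scatter of compound 1, and compound 3 alone stands apart from the other two. No measurement at hand accounts for the lower number of compound 3.

The group entering in compound 3 differs from the other two in ring make-up and in hetero atoms at once, so the shown compounds cannot say which of these features goes with the lower number. Also open, from the compounds shown here alone, is how a plain phenyl ring, or a pyridine ring carrying an amine or a carboxylic acid, would read on this carbonyl carbon with the shared core unchanged.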